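From Iodo to Ethynyl: An Expected Gain

The source may report more compounds than this note shows. Statements on the series, on what has been measured and on what is new or still open speak of the compounds shown alone.

In a functional assay on NCI-H522 cells (Homo sapiens) for cytotoxicity, with a stated time of 3 days (on this read-out higher numbers stand for weaker inhibition and lower numbers for stronger inhibition), compound 3 (`Ic1nc2ccccc2o1`) gives 11700 nM. This is level, within the scatter, with compound 1 (`C=Cc1nc2ccccc2[se]1`) at 12200 nM. Both stand far from compound 2 (`C#Cc1nc(C(=O)N2CCN(c3ccc(Cl)cc3)CC2)cs1`), which gives 28 nM, a much lower number and beyond the scatter. Compound 4 (`C#Cc1nc2ccccc2o1`) departs from compound 3 at one place: ethynyl in place of iodo on an aromatic carbon. For the measured compounds named here, no measured pair shows this change directly. Compound 2 also carries ethynyl and gives 28 nM, but the rest of its structure differs as well, so only a moderate gain in inhibition is expected in this assay. The expected step is a 7.8-fold lower number from compound 3 to compound 4 (0.89 log units; beyond the scatter). For compound 4 the estimated value is 1500 nM, with an expected range of 200 nM to 11000 nM.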

Compound 4, half-maximal inhibitory concentration: 1260 nM
Beside the measured number, compound 4's estimate is 1.2-fold (0.08 log units) above it, and the stated range covers the measured number.
By their numbers in this assay, from the lowest: compound 2; then compound 4; then compounds 3 and 1 (each within the scatter of the next).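

In this assay this position now has a direct reading: ethynyl in place of iodo on an aromatic carbon, next to the ring nitrogen and next to the ring oxygen, gives a 9.3-fold lower number from compound 3 to compound 4 (0.97 log units; beyond the scatter) and so lowers the number beyond the scatter. The gain comes with one more heavy atom and no added hydrogen-bond donors or acceptors. Nothing available explains this gain. From the compounds shown here alone, whether an amine or a carboxylic acid at this place would lower the number further remains open. So does whether a longer chain carrying the triple bond would keep the gain.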